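The compounds below may be only part of what the source reports. "The series", "measured", "known", "first", "only" and "open" are said of these compounds alone.

Working notes on the series. Compound 2 `C=CC[C@@H]1C[C@@H](c2ccc(Cl)c(Cl)c2)[C@H](NC(=O)c2cc(-c3c(Cl)cnn3C)c(Cl)o2)CN1` in a functional assay on OVCAR-8 cells (Homo sapiens) for antiproliferative activity (on this read-out higher numbers stand for weaker inhibition and lower numbers for stronger inhibition), gives 990 nM; compound 1 `Cn1ncc(Cl)c1-c1cc(C(=O)N[C@@H]2CN[C@H](CCn3cncn3)C[C@H]2c2ccc(Cl)c(Cl)c2)oc1Cl` gives 1560 nM, and the measured step between them is a 1.6-fold lower number from compound 1 to compound 2 (0.20 log units; within the scatter). Compound 3 `COCC[C@@H]1C[C@@H](c2ccc(Cl)c(Cl)c2)[C@H](NC(=O)c2cc(-c3c(Cl)cnn3C)c(Cl)o2)CN1` has not been measured yet. It differs from compound 2 by methoxymethyl in place of vinyl on a saturated chain carbon bound to a saturated ring carbon. Among the measured compounds shown here, the only step in hand at this chain position, a 1.6-fold lower number from compound 1 to compound 2 (0.20 log units; within the scatter), exchanged the substituent on the same carbon and stayed within the scatter, so it offers no sign of a large effect from a further change there. For compound 3 a step within the scatter is therefore expected, in either direction, as a 1.0-fold higher number from compound 2 to compound 3 (0.00 log units; within the scatter). Compound 3 is estimated at 1000 nM in this assay, with a range from 400 nM to 2500 nM.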

Compound 3, half-maximal inhibitory concentration: 1060 nM
For compound 3 the middle estimate is 1.1-fold (0.03 log units) below the measured one, and the stated range covers the measured number.
By their numbers in this assay, from the lowest: compounds 2, 3 and 1 (each within the scatter of the next).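

Methoxymethyl in place of vinyl on a saturated chain carbon bound to a saturated ring carbon gives a 1.1-fold higher number from compound 2 to compound 3 (0.03 log units; within the scatter) and so adds a hydrogen-bond acceptor and removes a double bond outside aromatic rings without a step beyond the scatter. Methoxy in place of 1H-1,2,4-triazol-1-yl gives a 1.5-fold lower number from compound 1 to compound 3 (0.17 log units; within the scatter) and thus all three chain ends shown lie within the scatter of each other. No measurement offered here accounts for this flat result.

From the compounds shown here alone, whether an amine, a carboxylic acid or a longer chain at this place would produce a step beyond the scatter remains open.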